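Dropping a methoxy group: what to expect for compound 4

This account rests on a few compounds, and the source may have more. Where it says the series, first, only, none or still open, it means among the compounds named here.

In a functional assay on EA.hy 926 cells (Homo sapiens) for cytotoxicity, read by MTT assay, with stated times of 24 h and 12 h, tested at 25 uM (on this read-out lower numbers stand for a weaker effect and higher numbers for a stronger effect at the one concentration tested), compound 3 `CCOC(=O)/C=C/c1cc(OC)c(OC(=O)c2nc(C)c(C)nc2C)c(OC)c1` gives 20.9%, the lowest of the three numbers. Compound 1 `COc1cc(/C=C/C(=O)O)ccc1OC(=O)c1nc(C)c(C)nc1C` gives 40.3% and compound 2 `CCOC(=O)/C=C/c1ccc(OC(=O)c2nc(C)c(C)nc2C)c(O)c1` gives 207%, and both lie beyond the scatter above compound 3. Compound 4 `CCOC(=O)/C=C/c1ccc(OC(=O)c2nc(C)c(C)nc2C)c(OC)c1` has not yet been measured. It differs from compound 3 in one place: hydrogen in place of methoxy on an aromatic carbon. Since compound 1 also sits low in this assay with 40.3%, only a modest rise is expected. The expected step is a number 19.1 percentage points higher from compound 3 to compound 4 (beyond the scatter), upward but possibly within the scatter. Compound 4 is therefore expected to give 40%, within a range of 15% to 90%.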

Compound 4, a percentage reported as activity, at one concentration (the size of the read-out at that concentration, not a potency): 53.3%
Compound 4: middle estimate off by 13.3 percentage points, on the low side, within the range that was stated.
By their numbers in this assay, from the lowest: compound 3; then compound 1; then compound 4; then compound 2.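

In this assay, hydrogen in place of methoxy on the aromatic carbon ortho to a large group gives a number 32.4 percentage points higher from compound 3 to compound 4 (beyond the scatter) and shows that the read-out responds to a change at this position. Compound 4 also connects the other two compounds through single changes: methyl in place of hydrogen on the oxygen on the aromatic ring gives a number 153.7 percentage points lower from compound 2 to compound 4 (beyond the scatter) and is a large step, whereas ethyl in place of hydrogen on the oxygen next to the carbonyl group gives only a modest one, a number 13 percentage points higher from compound 1 to compound 4 (beyond the scatter) in this series. As far as these compounds go, whether an amine or a longer chain on this carbon would move the number further remains open. What lies behind these steps also stays open, as nothing measured here speaks to it.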